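Methylsulfonyl for hydroxy on the two-carbon chain

The source may hold more compounds than are shown below. What is called first, only, known or untested is meant among the compounds shown, and "the series" means these compounds.

Measured compounds:
Compound 1 `O=P(O)(O)OCc1nc(Nc2ccc(C(F)(F)F)cc2)c2ccc(-c3ncccc3C(F)(F)F)cc2n1` gives 46 nM in a functional assay for antagonist activity at transient receptor potential cation channel subfamily V member 1 (Homo sapiens); on this read-out lower numbers stand for stronger inhibition and higher numbers for weaker inhibition.
Compound 2 `O=C(O)COCc1nc(Nc2ccc(C(F)(F)F)cc2)c2ccc(-c3ncccc3C(F)(F)F)cc2n1` gives 81 nM in this assay.
Compound 3 `OCCc1nc(Nc2ccc(C(F)(F)F)cc2)c2ccc(-c3ncccc3C(F)(F)F)cc2n1` gives 22 nM in this assay.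

Compound 3 stands lowest of the three numbers. Both steps that lead to it are beyond the scatter, though modest: a 2.1-fold lower number from compound 1 to compound 3 (0.32 log units; beyond the scatter) and a 3.7-fold lower number from compound 2 to compound 3 (0.57 log units; beyond the scatter). The third step, a 1.8-fold higher number from compound 1 to compound 2 (0.25 log units; within the scatter), lies within the scatter, so the two larger groups at that place cannot be told apart.

Compound 4 `CS(=O)(=O)CCc1nc(Nc2ccc(C(F)(F)F)cc2)c2ccc(-c3ncccc3C(F)(F)F)cc2n1` differs from compound 3 in one place: methylsulfonyl in place of hydroxy on a saturated chain carbon, two bonds along the chain from an aromatic carbon. Among the measured compounds shown here, no measured step exchanges hydroxy for methylsulfonyl, so the expectation rests on the two steps that end at compound 3, in which a small hydroxy-bearing end replaced a larger acid-bearing end and the number fell. Compound 4 moves the other way, from a small group to a larger one without a donor; by analogy a modestly higher number is expected, though the change is not the same and the analogy is loose.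

The step of a 2.3-fold higher number from compound 3 to compound 4 (0.36 log units; beyond the scatter) is therefore the expected outcome. Compound 4 is estimated at 50 nM in this assay, with a range from 15 nM to 160 nM.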

Compound 4, half-maximal inhibitory concentration: 36 nM
The estimate for compound 4 lay 1.4-fold (0.14 log units) above the measured number, within the range that was stated.
By their numbers in this assay, from the lowest: compounds 3, 4, 1 and 2 (each within the scatter of the next, the first and the last beyond it).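

Replacing hydroxy with methylsulfonyl at this place, on a saturated chain carbon two bonds along the chain from an aromatic carbon, gives a 1.6-fold higher number from compound 3 to compound 4 (0.21 log units; within the scatter) in this assay. The hydrogen-bond donor of hydroxy is therefore not needed to hold the number here, and a group of 4 heavy atoms with 0 hydrogen-bond donors is accommodated at this end of the chain. The other new steps divide the larger groups: a 1.3-fold lower number from compound 1 to compound 4 (0.11 log units; within the scatter) leaves compound 4 indistinguishable from the phosphate-bearing compound 1, whereas a 2.3-fold lower number from compound 2 to compound 4 (0.35 log units; beyond the scatter) sets compound 4 apart from the carboxymethoxy-bearing compound 2, and no available evidence bears on the reason for either outcome.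

The compounds shown leave open whether a primary amine or a methyl ether in place of hydroxy on the same saturated chain carbon would also stay within the scatter of compound 3. They also leave open whether a longer chain ending in methylsulfonyl or a sulfonamide at this end of the chain would preserve the number seen for compound 4.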